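Swapping Phenyl for Cyclopropyl on a Carbonyl

The source may hold more compounds than are shown below. What is called first, only, known or untested is meant among the compounds shown, and "the series" means these compounds.

In a functional assay on PC-3 cells (Homo sapiens) for inhibition, read by MTT assay, with a stated time of 48 h (a lower number here means a stronger inhibitor, a higher number a weaker inhibitor), compound 3 `COc1cc(-c2nnc(SCC(=O)c3ccccc3)n2-c2ccc(N(C)C)cc2)cc(OC)c1OC` gives 38600 nM and stands level with the other two measured compounds. Compound 2 `COc1cc(-c2nnc(SCc3ccc(C)cc3)n2-c2ccc(N(C)C)cc2)cc(OC)c1OC` gives 37300 nM and compound 1 `COc1ccc(-n2c(SCC(=O)C3CC3)nnc2-c2cc(OC)c(OC)c(OC)c2)cc1` gives 37200 nM on the same read-out, so no gap among the three goes beyond the scatter.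

The next compound to be tested is compound 4 `COc1cc(-c2nnc(SCC(=O)C3CC3)n2-c2ccc(N(C)C)cc2)cc(OC)c1OC`, which differs from compound 3 by cyclopropyl in place of phenyl on a carbonyl carbon. In other words, benzoyl gives way to cyclopropylcarbonyl.

Two pieces of evidence bear on this change. Going by the values given here, the only measured step in this part of the structure is benzoyl in place of 4-methylphenyl, and it was very small (a 1.0-fold higher number from compound 2 to compound 3 (0.01 log units; within the scatter)), well within the scatter. Among the compounds with values here, compound 4 also shares its cyclopropylcarbonyl group with compound 1 (37200 nM), although the two differ elsewhere in the structure, and that value lies within the scatter of the one for compound 3.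

Within the data shown here, nothing measured so far points to a shift in either direction, so in this assay the estimated move is a 1.0-fold lower number from compound 3 to compound 4 (0.02 log units; within the scatter) and none beyond the scatter is expected. For compound 4 the estimated value is 37000 nM (expected range 20000 nM to 68000 nM).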

Compound 4, half-maximal inhibitory concentration: 45900 nM
Estimate against measurement, compound 4: 1.2-fold (0.09 log units) below; the range from low to high includes it.
By their numbers in this assay, from the lowest: compounds 1, 2, 3 and 4 (each within the scatter of the next).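

In this assay, going by these compounds alone, cyclopropyl of 3 heavy atoms in place of phenyl of 6 heavy atoms on the carbonyl carbon gives a 1.2-fold higher number from compound 3 to compound 4 (0.08 log units; within the scatter) and so leaves the number level, which is the first direct reading of a change at this carbonyl carbon. Cyclopropylcarbonyl in place of 4-methylphenyl on the saturated chain carbon bound to a sulfur gives a 1.2-fold higher number from compound 2 to compound 4 (0.09 log units; within the scatter) as well, and dimethylamino in place of methoxy on an aromatic carbon, read here with the cyclopropylcarbonyl group held fixed, gives a 1.2-fold higher number from compound 1 to compound 4 (0.09 log units; within the scatter) as its step, so neither of these changes separates the compounds either. No outside evidence bears on this result.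

All four compounds stand level, so the compounds shown leave open whether any group on this carbonyl carbon can move the number beyond the scatter. An amine, a carboxylic acid or a longer chain in place of cyclopropyl on the carbonyl carbon would test that question, and the answer cannot be drawn from phenyl and cyclopropyl alone.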